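Methyl in place of methoxy: lipophilicity notes

This account rests on a few compounds, and the source may have more. Where it says the series, first, only, none or still open, it means among the compounds named here.

Measured so far in a physicochemical assay for lipophilicity; a lower number here means a more polar compound, a higher number a more lipophilic compound:
compound 1, `COc1c(OC)c(OC(C)=O)c2c(OC)cccc2c1OC(C)=O`: compound 1 gives 2.43
compound 2, `CCC(=O)Oc1c(OC)c(OC)c(OC(=O)CC)c2c(OC)cccc12`: compound 2 gives 3.44
compound 3, `COc1c(OC)c(OC(C)=O)c2c(C)cccc2c1OC(C)=O`: compound 3 gives 2.8

Compound 1 and compound 3 differ in one place only: methyl in place of methoxy on an aromatic carbon. In this assay that change made a step of a number 0.37 log units higher from compound 1 to compound 3 (beyond the scatter).

Compound 2 stands highest of the three in this assay; its gaps to compound 3 and to compound 1 both lie beyond the scatter. How the core of compound 2 differs from the core of compound 1 is not broken down here.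

Compound 4, `CCC(=O)Oc1c(OC)c(OC)c(OC(=O)CC)c2c(C)cccc12`, has not yet been measured. It differs from compound 2 by methyl in place of methoxy on an aromatic carbon. The place described for this change reads word for word as the place described for the change from compound 1 to compound 3, so this is the same change carried onto a second core, and it occurs twice among the compounds shown.

Going by the values given here, the step in this assay is expected to be a number 0.37 log units higher from compound 2 to compound 4 (beyond the scatter), because the single earlier step of a number 0.37 log units higher from compound 1 to compound 3 (beyond the scatter) is the only guide available and a second occurrence on another core may deviate from it. For compound 4 the expected value in this assay is 3.81, with a likely range from 3.5 to 4.1.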

Compound 4, partition coefficient: 3.9
The estimate for compound 4 lay 0.09 log units below the measured number, and the stated range covers the measured number.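

On the core of compound 2, methyl in place of methoxy on an aromatic carbon gives in this assay a step of a number 0.46 log units higher from compound 2 to compound 4 (beyond the scatter) and so runs the same way as the earlier step of a number 0.37 log units higher from compound 1 to compound 3 (beyond the scatter) on the other core, with both steps modest in size. These two pairs show that the change carried over in direction on the two cores shown, but they do not fix a constant increment for it, and they support no rule for any core other than those of compound 1 and compound 2. Nothing shown here explains the size or the direction of either step.

The compounds shown leave open whether a similar step would appear with another group at this place, such as ethyl, an amine or a carboxylic acid, since methoxy and methyl are the only two groups compared there. They also leave open whether the methyl for methoxy step would hold on a core carrying a longer chain, such as a hexyl chain, in place of the groups present on compound 1 and compound 2.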